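Replacing the carbonyl group of compound 2 with phenyl

The source may hold more compounds than are shown below. What is called first, only, known or untested is meant among the compounds shown, and "the series" means these compounds.

Going by the values given here, in a physicochemical assay for lipophilicity, using the shake flask method, in phosphate buffer, measured as octanol-water partition, with a stated time of 30 min, at pH 7.4 (a lower number here means a more polar compound, a higher number a more lipophilic compound), compound 2 (`O=C(Nc1cnc(NCc2c(F)ccc3c2CCO3)n2cnnc12)c1cccnc1`) gives 2 as the lower of the two numbers so far, and compound 1 (`CN(c1ccccc1)c1cnc(NCc2c(F)ccc3c2CCO3)n2cnnc12`) gives 3.6 as the higher one. Compound 3 (`Fc1ccc2c(c1CNc1ncc(Nc3ccccc3)c3nncn13)CCO2`) comes from compound 2 by a single change, phenyl in place of (pyridin-3-yl)carbonyl on a nitrogen on an aromatic ring in words phenyl in place of (pyridin-3-yl)carbonyl on a nitrogen on an aromatic ring. Among the compounds with values here, only one measured step bears on this change: a number 1.60 log units lower from compound 1 to compound 2 (beyond the scatter) is large and beyond the scatter, and it arrives at the same ((pyridin-3-yl)carbonyl)amino group that now leaves. Here anilino enters rather than methyl(phenyl)amino, and one step is thin support, so only most of that size is expected back. The expected move, a number 1.30 log units higher from compound 2 to compound 3 (beyond the scatter) in this assay, is upward and large. For compound 3 the estimated value is 3.3 within an expected range of 2.8 to 3.8 for this measurement.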

Compound 3, distribution coefficient: 3.3
Compound 3: the middle estimate sits on the measured number at the digits printed; measured number inside the range.
By their numbers in this assay, from the lowest: compound 2; then compounds 3 and 1 (each within the scatter of the next).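

In this assay, the step of a number 1.30 log units higher from compound 2 to compound 3 (beyond the scatter) shows that exchanging (pyridin-3-yl)carbonyl for phenyl on a nitrogen on an aromatic ring is a large change on its own, with no methyl involved. Hydrogen in place of methyl on that nitrogen gives a number 0.30 log units lower from compound 1 to compound 3 (within the scatter), so the methyl makes no difference that can be read here, and the large earlier step between compound 1 and compound 2, which changed both at once, matches the exchange of the other substituent on that nitrogen. No measurement offers a reason for the size of this step.

The compounds shown do not separate the carbonyl from the ring nitrogen of the pyridin-3-yl group, which a benzoyl group on the same nitrogen would do. As far as these compounds go, how a carboxylic acid or an amine on the phenyl ring would read at this position also remains open.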